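A few compounds are considered here, and "the series" means these few. Any claim that something is new, unique, unknown or untested is made for them only; others in the source may bear on it.

Among the three compounds measured so far, compound 3 `COc1cc(Cn2cc(CNC(=O)c3cn(-c4ccccc4)nc3-c3ccc(Cl)cc3)nn2)cc(OC)c1OC` stands lowest in a functional assay on HeLa cells (Homo sapiens) for antiproliferative activity, read by sulforhodamine B assay, with a stated time of 48 h (a higher number here means a weaker inhibitor of growth, a lower number a stronger inhibitor of growth), at 100 nM. Compound 2 `COc1cc(Cn2cc(CNC(=O)c3cn(-c4ccccc4)nc3-c3ccc(Cl)cc3)nn2)cc(OC)c1` gives 730 nM, and compound 1 `COc1ccc(Cn2cc(CNC(=O)c3cn(-c4ccccc4)nc3-c3ccc(Cl)cc3)nn2)cc1` gives 1400 nM. Two of these gaps are beyond the scatter: a 7.3-fold lower number from compound 2 to compound 3 (0.86 log units; beyond the scatter), and a 14-fold lower number from compound 1 to compound 3 (1.15 log units; beyond the scatter). The third is not: a 1.9-fold lower number from compound 1 to compound 2 (0.28 log units; within the scatter). All three steps alter only the methoxy pattern on the ring attached to the saturated chain carbon bound to an aromatic nitrogen, and leave the rest of the shared core untouched.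

Compound 4 `COc1ccc(-c2nn(-c3ccccc3)cc2C(=O)NCc2cn(Cc3cc(OC)c(OC)c(OC)c3)nn2)cc1` alters a different part of the molecule: methoxy in place of chloro on an aromatic carbon. Going by the values given here, none of the measured steps touches this place or exchanges a chloro for a methoxy, so no measured step bears directly on this change. Compound 4 keeps the 3,4,5-trimethoxyphenyl of compound 3, the ring that accompanied the lowest number in this assay. With no guide to direction, a step within the scatter is expected, with a wide range to allow for either outcome: a 1.5-fold higher number from compound 3 to compound 4 (0.18 log units; within the scatter). Compound 4 is therefore estimated at 150 nM, with a range from 40 nM to 600 nM.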

Compound 4, concentration for 50% growth inhibition: 1700 nM
Beside the measured number, compound 4's estimate is 11-fold (1.05 log units) below it; the measured number lies above the stated range.
By their numbers in this assay, from the lowest: compound 3; then compounds 2, 1 and 4 (each within the scatter of the next, the first and the last beyond it).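

In this assay, going by these compounds alone, replacing the 4-chlorophenyl with a 4-methoxyphenyl gives a 17-fold higher number from compound 3 to compound 4 (1.23 log units; beyond the scatter), the first sign that this ring position, which no earlier step touched, strongly affects the number. Within the data shown here, compound 3 and compound 4 both carry the 3,4,5-trimethoxyphenyl, so that ring alone does not secure a low number, something the earlier compounds could not reveal since all of them kept the 4-chlorophenyl. Nothing available here explains why the number rises when methoxy replaces chloro on this ring.

With only chloro and methoxy shown at this position, it remains open whether the result follows from losing the chloro or from adding the methoxy, and a plain hydrogen, a fluoro, a bromo, a methyl or an amine at the same place would help separate the two. It is also open whether the same exchange would cost as much alongside the 3,5-dimethoxyphenyl or the 4-methoxyphenyl, since the change is shown only with the 3,4,5-trimethoxyphenyl in place.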